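The source may report more compounds than this note shows. Statements on the series, on what has been measured and on what is new or still open speak of the compounds shown alone.

Compound 1 `CC(C)=CCOc1cc(=O)n(CCCO)c2c1CC(CC=C(C)C)C(C)(C)C2` and compound 2 `COc1ccc(OCCCOc2cc(=O)n(CCCO)c3c2CC(CC=C(C)C)C(C)(C)C3)cc1` share one core. In a functional assay on PANC-1 cells (Homo sapiens) for inhibition, read by MTT assay, with a stated time of 24 h, tested at 10 uM (a higher number here means more inhibition at the concentration tested (going by the name of the read-out), a lower number less inhibition), compound 1 gives 7.5%, and compound 2 gives 4.1%; the two numbers lie within the scatter of each other, as a number 3.4 percentage points lower from compound 1 to compound 2 (within the scatter) shows. Compound 3 `CC(C)=CCC1Cc2c(OC(=O)Nc3cccc(F)c3)cc(=O)n(CCCO)c2CC1(C)C` differs from compound 1 in one place: (3-fluorophenyl)carbamoyl in place of 3-methylbut-2-en-1-yl on an oxygen on an aromatic ring. For the measured compounds named here, no measured step exchanges this group, so only the low level of both measured compounds guides the expectation. A step of a number 0.5 percentage points higher from compound 1 to compound 3 (within the scatter) is expected, meaning no change beyond the scatter, and compound 3 is estimated at 8% in this assay, between 0% and 25%.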

Compound 3, a percentage reported as inhibition, at one concentration (the size of the read-out at that concentration, not a potency): 0%
Beside the measured number, compound 3's estimate is 8 percentage points above it; the measured number falls inside the stated range.
By their numbers in this assay, from the lowest: compounds 3, 2 and 1 (each within the scatter of the next).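

Placing (3-fluorophenyl)carbamoyl on the oxygen in place of 3-methylbut-2-en-1-yl adds an aromatic ring and a hydrogen-bond donor, yet this assay shows a number 7.5 percentage points lower from compound 1 to compound 3 (within the scatter) and so no real change. Inhibition therefore stays low with this quite different group on the oxygen, as it does for the groups in compound 1 and compound 2. No supporting measurement is available to explain this result.

Going by these compounds, whether a chain ending in an amine or a carboxylic acid on this oxygen would raise inhibition remains open.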